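Benzoyl for Benzyl on a Glycosidic Oxygen

The source may report more compounds than this note shows. Statements on the series, on what has been measured and on what is new or still open speak of the compounds shown alone.

compound 1 `O=C(OC[C@H]1O[C@@H](OC[C@H](O)[C@@H](O)c2ccc(O)cc2)[C@H](O)[C@@H](O)[C@@H]1O)c1ccccc1` — > 10000 nM
compound 2 `O=C(OC[C@H]1O[C@@H](OC[C@H]2O[C@@H](OCc3ccccc3)[C@H](O)[C@@H](O)[C@@H]2O)[C@H](O)[C@@H](O)[C@@H]1O)c1ccccc1` — > 10000 nM

In an ADME assay on BGC-823 cells (Homo sapiens) for cytotoxicity (a lower number here means a stronger inhibitor, a higher number a weaker inhibitor), compound 1 gives > 10000 nM, which is a limit of the assay and not a number. Compound 2 gives > 10000 nM in this assay, again a limit. Compound 2 therefore stands where every shown value sits: the limit of > 10000 nM in this assay, at which 2 of the 2 values shown sit. Among the compounds with values here, no step between two measured compounds is available, and compounds 1 and 2 show nothing beyond two limits of the same kind.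

Compound 3 `O=C(OC[C@H]1O[C@@H](OC[C@H]2O[C@@H](OC(=O)c3ccccc3)[C@H](O)[C@@H](O)[C@@H]2O)[C@H](O)[C@@H](O)[C@@H]1O)c1ccccc1` differs from compound 2 in one place: benzoyl in place of benzyl on an oxygen on a saturated carbon. In this assay a step from compound 2 to compound 3 that goes beyond the usual scatter is not expected; rather, compound 3 is expected to stay at the same limit. Compound 3 is expected to give about 15000 nM in this assay, with a range from 6000 nM to 40000 nM. The step that the limit leaves unreadable from compound 2 to compound 3 is estimated to lie within the scatter, most likely reported again only as a limit.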

Compound 3, half-maximal inhibitory concentration: > 10000 nM
Compound 3 gave a limit, no number (the forecaster's own chance of this, stated with the estimate: 85%); the middle value is on the limit's open side.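

In this assay compound 3 gives > 10000 nM, a limit and not a number. Compound 2 also gives a limit, and the step between compound 2 and compound 3 cannot be read. The compounds shown leave open whether benzoyl and benzyl differ at all in this assay, and what number any of the three compounds would reach.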